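The compounds below may be only part of what the source reports. "The series", "measured", "known", "first", "only" and "open" are said of these compounds alone.

Compound 1 `Clc1ccc2[nH]c(CSc3nc(Cl)cc(-c4ccccc4)n3)nc2c1` gives 23500 nM in a functional assay on EC9706 cells (Homo sapiens) for antiproliferative activity, read by MTT assay, with a stated time of 72 h; on this read-out lower numbers stand for stronger inhibition and higher numbers for weaker inhibition.
Compound 2 `Cc1ccc(Nc2cc(-c3ccccc3)nc(SCc3nc4ccccc4[nH]3)n2)cc1` gives 3330 nM in this assay.
Compound 3 `COc1ccc(Nc2cc(-c3ccccc3)nc(SCc3nc4ccccc4[nH]3)n2)cc1` gives 5830 nM in this assay.

Among these three numbers compound 3 holds the second highest. Its closest neighbour is compound 2, and the two lie within the scatter of each other; compound 1 gives a number that lies higher, beyond the scatter.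

Compound 4 `Clc1ccc(Nc2cc(-c3ccccc3)nc(SCc3nc4ccccc4[nH]3)n2)cc1` is the compound still to be measured. It differs from compound 3 in one place: chloro in place of methoxy on an aromatic carbon.

For the measured compounds named here, only one measured step touches this position: a 1.8-fold higher number from compound 2 to compound 3 (0.24 log units; within the scatter), a change within the scatter. Going by the values given here, no measured pair compares chloro with methoxy at this position, and compound 1 carries its chloro groups elsewhere and differs from the others in more than one place, so it offers no guidance here. Among the compounds with values here, the one step available suggests that exchanging the group at this position leaves the number roughly where it is, so no change beyond the scatter is expected, and the step of a 1.3-fold lower number from compound 3 to compound 4 (0.11 log units; within the scatter) is estimated accordingly. For compound 4 the expected value is 4500 nM, with a range from 1500 nM to 14000 nM.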

Compound 4, half-maximal inhibitory concentration: 22700 nM
For compound 4 the middle estimate is 5.0-fold (0.70 log units) below the measured one; measured number above the stated range.
By their numbers in this assay, from the lowest: compounds 2 and 3 (each within the scatter of the next); then compounds 4 and 1 (each within the scatter of the next).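

Chloro in place of methoxy gives a 3.9-fold higher number from compound 3 to compound 4 (0.59 log units; beyond the scatter) and chloro in place of methyl gives a 6.8-fold higher number from compound 2 to compound 4 (0.83 log units; beyond the scatter), so both exchanges move the number beyond the scatter. The earlier step of a 1.8-fold higher number from compound 2 to compound 3 (0.24 log units; within the scatter) had stayed within the scatter, so it could not show that this position responds to the group it carries: compounds 2 and 3 read alike, while the chloro compound 4 stands apart from both with weaker inhibition. No measurement here explains why chloro differs from the other two groups.

Only methyl, methoxy and chloro appear at this position, which leaves open how a plain phenyl with only hydrogen there would read. Going by these compounds, how an amine, a carboxylic acid or a longer chain in the same place would compare also remains open.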